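The source may report more compounds than this note shows. Statements on the series, on what has been measured and on what is new or still open speak of the compounds shown alone.

Compound 1 `NC(=O)c1c(NC(=O)c2ccccc2Br)sc2c1CCN(C(=S)Nc1ccccc1Cl)C2` is the starting point of this small set. In a functional assay on MKN-74 cells (Homo sapiens) for antiproliferative activity, with a stated time of 24 h (a lower number here means a stronger inhibitor, a higher number a weaker inhibitor), compound 1 gives 12900 nM. Compound 2 `NC(=O)c1c(NC(=O)c2ccccc2I)sc2c1CCN(C(=S)Nc1ccccc1Cl)C2` differs from it only in one halogen: iodo in place of bromo on an aromatic carbon. In this assay compound 2 gives 17500 nM, and the step is a 1.4-fold higher number from compound 1 to compound 2 (0.13 log units; within the scatter). Compound 3 `NC(=O)c1c(NC(=O)c2ccccc2Br)sc2c1CCN(C(=S)Nc1ccccc1Br)C2` changes a different halogen: bromo in place of chloro on an aromatic carbon. In this assay compound 3 gives 13700 nM, so the step is a 1.1-fold higher number from compound 1 to compound 3 (0.03 log units; within the scatter). All three numbers lie close together.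

Compound 4 `NC(=O)c1c(NC(=O)c2ccccc2I)sc2c1CCN(C(=S)Nc1ccccc1Br)C2` has not yet been measured. It differs from compound 3 by iodo in place of bromo on an aromatic carbon. This is the same change already seen between compound 1 and compound 2, and the surroundings of the exchanged atom are the same in both pairs. The two cores differ from each other by bromo in place of chloro on an aromatic carbon.

Since that earlier step was a 1.4-fold higher number from compound 1 to compound 2 (0.13 log units; within the scatter), compound 4 is expected to show a step of about a 1.3-fold higher number from compound 3 to compound 4 (0.12 log units; within the scatter) from compound 3, because a 1.4-fold higher number from compound 1 to compound 2 (0.13 log units; within the scatter) was small. Compound 4 is therefore estimated at 18000 nM, most likely between 9000 nM and 36000 nM.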

Compound 4, half-maximal inhibitory concentration: 22400 nM
The estimate for compound 4 lay 1.2-fold (0.09 log units) below the measured number; the measured number falls inside the stated range.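

In this assay, for the compounds shown here, iodo in place of bromo on the core of compound 3 gives a 1.6-fold higher number from compound 3 to compound 4 (0.21 log units; within the scatter), and bromo in place of chloro on the core of compound 2 gives a 1.3-fold higher number from compound 2 to compound 4 (0.11 log units; within the scatter); each step is small, so the agreement described next shows only that these halogen exchanges stay small on both cores, not that a larger effect would carry over in the same way. The iodo exchange gives a step of matching size on the two cores: the same change on two cores in this assay, a 1.4-fold higher number (0.13 log units; within the scatter) from compound 1 to compound 2 and a 1.6-fold higher number (0.21 log units; within the scatter) from compound 3 to compound 4, 1.2-fold (0.08 log units) apart, within the scatter of two such steps. The bromo exchange does the same: the same change on two cores in this assay, a 1.1-fold higher number (0.03 log units; within the scatter) from compound 1 to compound 3 and a 1.3-fold higher number (0.11 log units; within the scatter) from compound 2 to compound 4, 1.2-fold (0.08 log units) apart, within the scatter of two such steps.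

The compounds shown vary only chloro, bromo and iodo, and they leave open whether a change that moves the number beyond the scatter would also carry from one core to the other. They also leave open what an amine, a carboxylic acid or a longer chain in place of these halogens would do in this assay.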